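The compounds below may be only part of what the source reports. "The series", "measured", "known", "first", "only" and "open" are said of these compounds alone.

In a functional assay on L1210 cells (Mus musculus) for antiproliferative activity, read by sulforhodamine B assay, with a stated time of 48 h (a higher number here means a weaker inhibitor, a lower number a stronger inhibitor), compound 1 `Cc1cccc(NS(=O)(=O)c2ccc(N3CCNC3=O)cc2)c1` gives 180 nM, compound 2 `CCc1cccc(NS(=O)(=O)c2ccc(N3CCNC3=O)cc2)c1` gives 200 nM and compound 3 `Cc1cc(C)cc(NS(=O)(=O)c2ccc(N3CCNC3=O)cc2)c1` gives 110 nM. Compound 3 therefore stands level with the other two, within the scatter. Compound 4 `Cc1ccc(C)c(NS(=O)(=O)c2ccc(N3CCNC3=O)cc2)c1` carries the same atoms as compound 3, joined differently: 2,5-dimethylphenyl in place of 3,5-dimethylphenyl on a sulfonamide nitrogen. The measured steps that bear on this are a 1.6-fold lower number from compound 1 to compound 3 (0.21 log units; within the scatter), a 1.8-fold lower number from compound 2 to compound 3 (0.26 log units; within the scatter) and a 1.1-fold higher number from compound 1 to compound 2 (0.05 log units; within the scatter), and all three stay within the scatter. None of them produces a 2,5-dimethylphenyl on the sulfonamide nitrogen, so they guide the expectation only loosely, and the range must stay wide. The expected step is a 1.7-fold higher number from compound 3 to compound 4 (0.24 log units; within the scatter), a modest estimated rise that stays within the scatter. For compound 4 the estimated value is 190 nM, with an expected range from 70 nM to 500 nM.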

Compound 4, half-maximal inhibitory concentration: 81 nM
The estimate for compound 4 lay 2.3-fold (0.37 log units) above the measured number, and the stated range covers the measured number.
By their numbers in this assay, from the lowest: compounds 4, 3, 1 and 2 (each within the scatter of the next, the first and the last beyond it).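

Swapping 3,5-dimethylphenyl for 2,5-dimethylphenyl on the sulfonamide nitrogen gives a 1.4-fold lower number from compound 3 to compound 4 (0.13 log units; within the scatter) in this assay, so moving one methyl group leaves the two compounds level. Unlike the earlier compounds, whose steps all stayed within the scatter, compound 4 separates modestly from two others, with a 2.2-fold lower number from compound 1 to compound 4 (0.35 log units; beyond the scatter) and a 2.5-fold lower number from compound 2 to compound 4 (0.39 log units; beyond the scatter) as the steps. Nothing available explains these differences. Still open, from the compounds shown here alone, is whether a chlorine atom or a methoxy group in place of these methyl groups would keep the numbers at this level.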